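Reversing the enone and adding a second methyl

A few compounds are considered here, and "the series" means these few. Any claim that something is new, unique, unknown or untested is made for them only; others in the source may bear on it.

Measured compounds: compound 1 `COc1ccc(/C=C/C(=O)c2cc(-c3ccc(OC)c(OC)c3)n3nc(-c4ccccc4)cc3n2)cc1`, 22000 nM; compound 2 `COc1ccc(-c2cc(C(=O)/C=C/c3ccc(Cl)cc3)nc3cc(-c4ccccc4)nn23)cc1OC`, 23700 nM; compound 3 `COc1ccc(-c2cc(C(=O)/C=C/c3ccc(C)cc3)nc3cc(-c4ccccc4)nn23)cc1OC`, 22600 nM.

All three numbers come from a functional assay on MDA-MB-231 cells (Homo sapiens) for antiproliferative activity, read by MTT assay, with a stated time of 24 h; a higher number here means a weaker inhibitor, a lower number a stronger inhibitor. Compound 3 sits indistinguishably among the other two: the step of a 1.0-fold higher number from compound 1 to compound 3 (0.01 log units; within the scatter) and the step of a 1.0-fold lower number from compound 2 to compound 3 (0.02 log units; within the scatter) both lie within the scatter, as does the step of a 1.1-fold higher number from compound 1 to compound 2 (0.03 log units; within the scatter). Across the three measured compounds, then, the numbers in this assay do not move beyond repeat-measurement noise.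

Compound 4 `COc1ccc(-c2cc(/C=C/C(=O)c3ccc(C)c(C)c3)nc3cc(-c4ccccc4)nn23)cc1OC` is not yet measured. It differs from compound 3 in one place: 2-((3,4-dimethylphenyl)carbonyl)ethenyl in place of (2-(4-methylphenyl)ethenyl)carbonyl on an aromatic carbon. Two things change at once here, the direction of the carbonyl-bearing ethenyl chain and the substitution on the phenyl ring at its far end. Compound 1 carries its chain in the same direction as compound 4, and its number in this assay is within the scatter of compound 3. None of the three measured steps tests the chain direction or the 3,4-dimethylphenyl group directly.

On that basis the expected step of a 1.0-fold lower number from compound 3 to compound 4 (0.01 log units; within the scatter) is none beyond the scatter. Compound 4 is estimated at 22000 nM in this assay, with a range of 10000 nM to 48000 nM.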

Compound 4, half-maximal inhibitory concentration: 11500 nM
Compound 4: middle estimate off by 1.9-fold (0.28 log units), on the high side, within the range that was stated.
By their numbers in this assay, from the lowest: compounds 4, 1, 3 and 2 (each within the scatter of the next, the first and the last beyond it).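

In this assay, for the compounds shown here, the replacement at this aromatic carbon, opposite the ring nitrogen, produces the first step that lies beyond the scatter: a 2.1-fold lower number from compound 2 to compound 4 (0.31 log units; beyond the scatter), a modest one. Going by these compounds alone, the same replacement remains within the scatter against the other two compounds, with a 2.0-fold lower number from compound 3 to compound 4 (0.29 log units; within the scatter) and a 1.9-fold lower number from compound 1 to compound 4 (0.28 log units; within the scatter), so the separation holds for only one of the three pairs and is no general shift across the series. The earlier exchanges of methoxy, chloro and methyl on the far phenyl ring separated no pair at all, whereas this change to the whole chain shows that 2-((3,4-dimethylphenyl)carbonyl)ethenyl is accommodated here and can separate compound 4 from compound 2, though nothing available accounts for that difference.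

The direction of the chain and the substitution on its phenyl ring change together, so the compounds shown cannot assign the step to either one. Also open, as far as these compounds go, is how this position would respond to a saturated ethyl linker in place of the ethenyl unit, or to an amine or a carboxylic acid on the far phenyl ring.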